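Working notes: replacing the pyrrolidine side group of compound 3

The source may report more compounds than this note shows. Statements on the series, on what has been measured and on what is new or still open speak of the compounds shown alone.

Values in a functional assay on V79 cells (Cricetulus griseus) for cytotoxicity, read by colony formation; a higher number here means a weaker inhibitor, a lower number a stronger inhibitor:
- compound 1 `COc1c(N2CCC(N)C2)c(F)cc2c(=O)c(C(=O)O)cn(C3CC3)c12` gives 45 ug/mL; 44 ug/mL; 45 ug/mL (3 entries)
- compound 2 `CCNCC1CCN(c2c(F)cc3c(=O)c(C(=O)O)cn(C4CC4)c3c2OC)C1` gives 22 ug/mL; 22 ug/mL (2 entries)
- compound 3 `CNCC1(C)CCN(c2c(F)cc3c(=O)c(C(=O)O)cn(C4CC4)c3c2OC)C1` gives 120 ug/mL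

The number for compound 3 is the only one shown for it, and two further entries for the same compound carry no single number. It stands apart from the other two values, which lie close to each other.

Compound 4 `COc1c(N2CCNCC2)c(F)cc2c(=O)c(C(=O)O)cn(C3CC3)c12` keeps the shared core and has not yet been measured. In it, piperazin-1-yl takes the place of 3-methyl-3-((methylamino)methyl)pyrrolidin-1-yl on an aromatic carbon, ortho to a fluoro group and ortho to a methoxy group (piperazin-1-yl in place of 3-methyl-3-((methylamino)methyl)pyrrolidin-1-yl on an aromatic carbon).

Among the measured compounds shown here, no measured step isolates this change. The expectation therefore leans on the other two compounds, with compound 1 at 45 ug/mL; 44 ug/mL; 45 ug/mL (3 entries) and compound 2 at 22 ug/mL; 22 ug/mL (2 entries). The expected move is a 2.4-fold lower number from compound 3 to compound 4 (0.38 log units; beyond the scatter), toward a lower number in this assay and modestly beyond the usual scatter, with wide uncertainty. For compound 4 the estimated value is 50 ug/mL, with an expected range from 20 ug/mL to 120 ug/mL.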

Compound 4, half-maximal inhibitory concentration: 82 ug/mL
Beside the measured number, compound 4's estimate is 1.6-fold (0.21 log units) below it, and the stated range covers the measured number.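

Among the compounds shown here, at this position, on an aromatic carbon ortho to a fluoro group and ortho to a methoxy group, the first direct step in this assay is a 1.5-fold lower number from compound 3 to compound 4 (0.17 log units; within the scatter). Compound 3 and compound 4 therefore cannot be told apart in this read-out, even though a five-membered non-aromatic ring with 1 hetero atom gives way to a six-membered one with 2 hetero atoms, at equal hydrogen-bond donor and acceptor counts. Repeat readings of one compound in this series agree closely: the several entries of compound 1 in this assay, 45 ug/mL; 44 ug/mL; 45 ug/mL (3 entries)

Compound 3 rests on one shown number, so the size of this step remains tied to that single reading. Still open, as far as these compounds go, is whether morpholin-4-yl, with a ring oxygen in place of the second ring nitrogen, or a piperazin-1-yl carrying a methyl group would stay in the same range here.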